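The source may hold more compounds than are shown below. What is called first, only, known or untested is meant among the compounds shown, and "the series" means these compounds.

Measured compounds:
Compound 1 `CC1=C(C(=O)OC2CCCCC2)C(c2ccco2)NC(=O)N1` gives 4%
Compound 2 `CC1=C(C(=O)OCC2CC2)C(c2ccco2)NC(=O)N1` gives 1%
Compound 3 `CC1=C(C(=O)OC2CCCCC2)C(c2cccs2)NC(=O)N1` gives 1%

In an assay on membranes from HeLa cells for displacement of a labelled ligand from adenosine receptor A3 (Homo sapiens), read by scintillation counting, with a stated time of 180 min, tested at 1 uM (on this read-out higher numbers stand for more inhibition at the one concentration tested (going by the name of the read-out) and lower numbers for less inhibition), all three measured compounds sit low, and their steps stay within the scatter. From compound 1 the change cyclopropylmethyl in place of cyclohexyl on an oxygen next to a carbonyl group gave a number 3 percentage points lower from compound 1 to compound 2 (within the scatter). The cores of compound 1 and compound 3 differ by thiophen-2-yl in place of furan-2-yl on a saturated ring carbon, a change that gave a number 3 percentage points lower from compound 1 to compound 3 (within the scatter). Compound 3 stands level with compound 2 at the digits reported, and both together are the lowest of the three numbers.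

Compound 4 `CC1=C(C(=O)OCC2CC2)C(c2cccs2)NC(=O)N1` has not yet been measured in this assay. It differs from compound 3 by cyclopropylmethyl in place of cyclohexyl on an oxygen next to a carbonyl group, the same change that was made from compound 1 to compound 2, at the same place. Since that change once gave a number 3 percentage points lower from compound 1 to compound 2 (within the scatter), a step within the scatter, and compound 3 already gives 1%, the step from compound 3 to compound 4 is expected to be no change at the digits printed from compound 3 to compound 4 (within the scatter). The estimate for compound 4 in this assay is 1%, with an expected range from -8% to 10%.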

Compound 4, a percentage reported as inhibition, at one concentration (the size of the read-out at that concentration, not a potency): 1%
Compound 4: the middle estimate sits on the measured number at the digits printed; the range from low to high includes it.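

In this assay, cyclopropylmethyl in place of cyclohexyl on an oxygen next to a carbonyl group gave no change at the digits printed from compound 3 to compound 4 (within the scatter), and set beside the earlier step this reads: the same change on two cores in this assay, a number 3 percentage points lower (within the scatter) from compound 1 to compound 2 and no change at the digits printed (within the scatter) from compound 3 to compound 4, 3 percentage points apart, within the scatter of two such steps. Thiophen-2-yl in place of furan-2-yl on a saturated ring carbon gave no change at the digits printed from compound 2 to compound 4 (within the scatter), and here the comparison reads: the same change on two cores in this assay, a number 3 percentage points lower (within the scatter) from compound 1 to compound 3 and no change at the digits printed (within the scatter) from compound 2 to compound 4, 3 percentage points apart, within the scatter of two such steps. This agreement holds only among four numbers that all sit low, with every step inside the scatter, so it does not show that either change would behave alike on a compound giving a clearly higher number.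

The compounds shown leave open whether another group on that oxygen, such as a longer chain or a chain ending in an amine, would give a number beyond the scatter of these four. They also leave open what a phenyl ring on the saturated ring carbon would give, in place of furan-2-yl or thiophen-2-yl.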